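Methoxy on the aryl ether in two cores

The source may hold more compounds than are shown below. What is called first, only, known or untested is meant among the compounds shown, and "the series" means these compounds.

The series holds two cores. Compound 2 `C/C(=C\COc1ccccc1)CC/C=C(\C)C1CC(=O)C(C)(C)O1` and compound 3 `C/C(=C\COc1ccccc1)CC/C=C(\C)C1=CC(=O)C(C)(C)O1` share the phenyl ether chain; their cores differ by a group of 8 heavy atoms (6 carbon, 2 oxygen; one five-membered non-aromatic ring with 1 hetero atom) in place of a group of 8 heavy atoms (6 carbon, 2 oxygen; one five-membered non-aromatic ring with 1 hetero atom), on a double-bonded chain carbon bound to a double-bonded chain carbon and a saturated chain carbon, a change that gave a 1.3-fold lower number from compound 2 to compound 3 (0.13 log units; within the scatter). Compound 1 `COc1cccc(OC/C=C(\C)CC/C=C(\C)C2CC(=O)C(C)(C)O2)c1` carries a methoxy that compound 2 lacks: methoxy in place of hydrogen on an aromatic carbon, a step of a 1.2-fold higher number from compound 2 to compound 1 (0.07 log units; within the scatter). In a functional assay on FM3A cells (Mus musculus) for inhibition (on this read-out higher numbers stand for weaker inhibition and lower numbers for stronger inhibition), compound 1 gives 68.7 ug/mL, compound 2 gives 59 ug/mL and compound 3 gives 44.2 ug/mL. Compound 4 `COc1ccc(OC/C=C(\C)CC/C=C(\C)C2=CC(=O)C(C)(C)O2)cc1` is not yet measured; it differs from compound 3 by methoxy in place of hydrogen on an aromatic carbon. For the measured compounds named here, this is the same kind of change as the one to compound 1, not the same: there the methoxy sits meta to a large group, here para to a large group. The step to compound 4 is expected to be small, a 1.1-fold higher number from compound 3 to compound 4 (0.05 log units; within the scatter), because the like step a 1.2-fold higher number from compound 2 to compound 1 (0.07 log units; within the scatter) stayed within the scatter. Compound 4 is estimated at 50 ug/mL, between 30 ug/mL and 85 ug/mL.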

Compound 4, half-maximal inhibitory concentration: 43.8 ug/mL
Compound 4: middle estimate off by 1.1-fold (0.06 log units), on the high side; the measured number falls inside the stated range.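

In this assay, methoxy in place of hydrogen on the aromatic ring gives a 1.0-fold lower number from compound 3 to compound 4 (0.00 log units; within the scatter), and the two cores agree on this change: the same change on two cores in this assay, a 1.2-fold higher number (0.07 log units; within the scatter) from compound 2 to compound 1 and a 1.0-fold lower number (0.00 log units; within the scatter) from compound 3 to compound 4, 1.2-fold (0.07 log units) apart, within the scatter of two such steps. Both steps lie within the scatter, so the methoxy carries across these two cores with no readable effect on either, and the agreement is one of two null results, not of two matching measurable effects. It also does not isolate the core as the only variable, since the methoxy stands para to a large group in compound 4 and at a different ring position in compound 1.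

Still open, as far as these compounds go, is whether the same two cores would also agree on a change that gives a step beyond the scatter. An amine, a carboxylic acid or a longer alkoxy chain on the aromatic ring would test this.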